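Lengthening the Ether Arm: From Benzyloxy to Phenethyloxy

This account rests on a few compounds, and the source may have more. Where it says the series, first, only, none or still open, it means among the compounds named here.

Compound 3 `CCc1sc(CCc2cc(OCc3ccccc3)cc(NCc3cc(Cl)cc(NC(=O)OC(C)C)c3)n2)nc1C` carries a benzyloxy group on its core and, in an assay on cells for binding affinity to Neuropeptide Y receptor type 1 (Homo sapiens) (a higher number here means a weaker inhibitor, a lower number a stronger inhibitor), gives 237 nM, the highest of the three numbers in hand. Its closest neighbours are compound 1 `CCOc1cc(CCc2nc(C)c(CC)s2)nc(NCc2cc(Cl)cc(NC(=O)OC(C)C)c2)c1` with 33 nM and compound 2 `CCc1sc(CCc2cc(OC3CCCCC3)cc(NCc3cc(Cl)cc(NC(=O)OC(C)C)c3)n2)nc1C` with 29 nM. The steps of a 7.2-fold higher number from compound 1 to compound 3 (0.86 log units; beyond the scatter) and an 8.2-fold higher number from compound 2 to compound 3 (0.91 log units; beyond the scatter) both show that placing the phenyl ring one carbon from the ring oxygen weakens binding. Compound 4 `CCc1sc(CCc2cc(OCCc3ccccc3)cc(NCc3cc(Cl)cc(NC(=O)OC(C)C)c3)n2)nc1C` pushes the ring one bond further out: benzyl in place of phenyl on a saturated chain carbon bound to an oxygen on an aromatic ring. Among the measured compounds shown here, no measured step covers this exact move, so the expectation rests only on the two steps above. Some recovery toward the alkyl ethers is expected, estimated as a 2.0-fold lower number from compound 3 to compound 4 (0.30 log units; within the scatter). For compound 4 the value in this assay is therefore expected near 120 nM, within 40 nM to 400 nM.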

Compound 4, half-maximal inhibitory concentration: 30 nM
For compound 4 the middle estimate is 4.0-fold (0.60 log units) above the measured one, outside the stated range (below it).
By their numbers in this assay, from the lowest: compounds 2, 4 and 1 (each within the scatter of the next); then compound 3.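

Phenethyloxy in place of benzyloxy gives a 7.9-fold lower number from compound 3 to compound 4 (0.90 log units; beyond the scatter) in this assay so a phenyl ring on this ether arm is compatible with the numbers of the alkyl ethers once one more chain carbon is present. The arm's end group also matters little across these three compounds, as a 1.0-fold higher number from compound 2 to compound 4 (0.01 log units; within the scatter) and a 1.1-fold lower number from compound 1 to compound 4 (0.04 log units; within the scatter) both lie within the scatter. Nothing available explains why benzyloxy alone stands apart.

As far as these compounds go, whether a longer chain such as phenylpropyloxy keeps this level remains open. So does whether an amine or a carboxylic acid at the end of the arm would be tolerated.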